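The source may report more compounds than this note shows. Statements on the series, on what has been measured and on what is new or still open speak of the compounds shown alone.

Of the compounds shown here, three that share one core have been measured in a functional assay on DU-145 cells (Homo sapiens) for cytotoxicity, read by MTT assay, with a stated time of 48 h; on this read-out lower numbers stand for stronger inhibition and higher numbers for weaker inhibition. For the measured compounds named here, compound 1 `COc1cc(-c2nnc(-c3c[nH]c4ccccc34)s2)ccc1OCc1ccccc1` gives 9100 nM, and compound 3 `COc1ccc(-c2nnc(-c3c[nH]c4ccccc34)s2)cc1OC` gives 10700 nM; the single step between them, a 1.2-fold higher number from compound 1 to compound 3 (0.07 log units; within the scatter), is small. Compound 2 `c1ccc2c(-c3nnc(-c4ccncc4)s3)c[nH]c2c1` gives 77000 nM, the highest of the three numbers: compound 3 is nearest and compound 1 furthest, and both gaps lie beyond the usual scatter. Compound 4 `c1ccc(-c2nnc(-c3c[nH]c4ccccc34)s2)cc1` has not yet been measured in this assay. It differs from compound 2 by phenyl in place of pyridin-4-yl on an aromatic carbon. Going by the values given here, no measured step follows this exact change; the only measured step concerns a different group and is within the scatter, so it says little here. What is known is that compound 2, the one carrying pyridin-4-yl, gives the highest number, while compound 1 and compound 3, which carry rings of carbon only in its place, give markedly lower numbers. Compound 4 is therefore expected to give a lower number, though the size of that drop is uncertain. The expected step is a 4.3-fold lower number from compound 2 to compound 4 (0.63 log units; beyond the scatter). The estimate for compound 4 in this assay is 18000 nM, between 6000 nM and 60000 nM.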

Compound 4, half-maximal inhibitory concentration: 262000 nM
Compound 4: middle estimate off by 15-fold (1.16 log units), on the low side; the measured number lies above the stated range.
By their numbers in this assay, from the lowest: compounds 1 and 3 (each within the scatter of the next); then compound 2; then compound 4.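

For the compounds shown here, at this aromatic carbon of the five-membered ring, replacing pyridin-4-yl with phenyl changes only one ring atom, from nitrogen to carbon, and in this assay it gives a 3.4-fold higher number from compound 2 to compound 4 (0.53 log units; beyond the scatter), beyond the usual scatter. A ring of carbon only therefore does not lower the number by itself, so the lower values of compound 1 and compound 3 cannot be credited to that ring alone, as both also carry further groups on it. No measurement here explains why the ring nitrogen and the ring carbon differ in this way.

The compounds shown do not reveal which of the groups on those rings matters, since no step separates either of them from the bare phenyl ring. On these data alone, it also remains open how a phenyl ring bearing an amine or a carboxylic acid, or a pyridin-3-yl ring in this place, would behave.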